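The source may hold more compounds than are shown below. What is called first, only, known or untested is meant among the compounds shown, and "the series" means these compounds.

The three compounds measured so far in a functional assay on T98G cells (Homo sapiens) for cytotoxicity, read by MTT assay, with a stated time of 48 h (on this read-out higher numbers stand for weaker inhibition and lower numbers for stronger inhibition), are:

compound 1, `C/C(=N\NC(=S)Nc1ccccc1I)c1ccccn1`, which gives 8.09 nM;
compound 2, `C/C(=N\NC(=S)Nc1ccccc1Cl)c1ccccn1`, which gives 1.1 nM;
compound 3, `CC(=NNC(=S)Nc1ccc(I)cc1)c1ccccn1`, which gives 64 nM.

Compound 1 and compound 2 share one core and differ in a single place, namely (chloro in place of iodo on an aromatic carbon). That exchange gave a step of a 7.4-fold lower number from compound 1 to compound 2 (0.87 log units; beyond the scatter), so compound 2 stands with the lowest number of the three. Compound 3 is built from the same atoms as compound 1 but joined differently; the difference between the two cores is not broken down here. In this assay compound 3 stands highest of the three, well apart from both compound 1 and compound 2.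

Compound 4, `CC(=NNC(=S)Nc1ccc(Cl)cc1)c1ccccn1`, has not yet been measured. It is related to compound 3 in the same way as compound 2 is related to compound 1: chloro in place of iodo on an aromatic carbon. The place is not the same word for word, since in compound 3 the group sits para to a large group, whereas in compound 1 it sits ortho to a large group, so this is the same kind of change rather than the same change.

Compound 4 is therefore expected to show a step of a 4.3-fold lower number from compound 3 to compound 4 (0.63 log units; beyond the scatter), which rests on the step of a 7.4-fold lower number from compound 1 to compound 2 (0.87 log units; beyond the scatter) seen for the matching exchange. The estimate for compound 4 in this assay is 15 nM, with an expected range from 4 nM to 60 nM.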

Compound 4, half-maximal inhibitory concentration: 5.9 nM
Compound 4: the middle estimate sits 2.5-fold (0.41 log units) above what was measured; measured number inside the range.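

Exchanging iodo for chloro on an aromatic carbon lowered the number on both cores in this assay, and the new result is an 11-fold lower number from compound 3 to compound 4 (1.04 log units; beyond the scatter). Set beside the earlier result, the two steps agree about as closely as two such steps can be expected to: the same change on two cores in this assay, a 7.4-fold lower number (0.87 log units; beyond the scatter) from compound 1 to compound 2 and an 11-fold lower number (1.04 log units; beyond the scatter) from compound 3 to compound 4, 1.5-fold (0.17 log units) apart, within the scatter of two such steps. This shows that, across these two pairs, the exchange carried over from one core to the other with a similar size, even though the halogen does not sit in the same place on the ring in the two pairs, but two pairs cannot show why chloro gives the lower number or whether the same step would appear on any further core.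

The compounds shown cover only iodo and chloro, so it remains open whether bromo or fluoro would fall in line with them, and what a methoxy group, a nitrile or an amine would do at the same positions. On these data alone, it also remains open whether the step between iodo and chloro would keep its size in cell lines other than the one tested here.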